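A few compounds are considered here, and "the series" means these few. Any claim that something is new, unique, unknown or untested is made for them only; others in the source may bear on it.

In an assay for binding affinity to dual specificity mitogen-activated protein kinase kinase 4 (Homo sapiens), read by KINOMEscan, tested at 100 nM (on this read-out lower numbers stand for a stronger effect and higher numbers for a weaker effect at the one concentration tested), compound 1 `CCCS(=O)(=O)Nc1ccc(F)c(C(=O)c2n[nH]c3ncc(-c4ccccc4Cl)cc23)c1F` gives 9.3%. Compound 2 `CCCS(=O)(=O)Nc1ccc(F)c(C(=O)c2n[nH]c3ncc(-c4ccccc4C)cc23)c1F` gives 7% in this assay, and compound 3 `CCCS(=O)(=O)Nc1ccc(F)c(C(=O)c2n[nH]c3ncc(-c4ccc(S(N)(=O)=O)cc4C)cc23)c1F` gives 3.1%. Compound 4 `CCCS(=O)(=O)Nc1ccc(F)c(C(=O)c2n[nH]c3ncc(-c4ccc(S(N)(=O)=O)cc4Cl)cc23)c1F` has not yet been measured. From compound 3 to compound 4 the change is chloro in place of methyl on an aromatic carbon. The same change has been made once already, from compound 2 to compound 1: chloro in place of methyl on an aromatic carbon, with a step of a number 2.3 percentage points higher from compound 2 to compound 1 (within the scatter). The two cores differ in that (sulfamoyl in place of hydrogen on an aromatic carbon). The surroundings of the place are not identical, as in compound 4 the place is also meta to a sulfamoyl group, so this counts as the same kind of change rather than the same one. For compound 4 in this assay a step of a number 1.9 percentage points higher from compound 3 to compound 4 (within the scatter) is expected, resting on the earlier step of a number 2.3 percentage points higher from compound 2 to compound 1 (within the scatter). Compound 4 is therefore estimated at 5%, likely between 1% and 12%.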

Compound 4, a percentage reported as activity, at one concentration (the size of the read-out at that concentration, not a potency): 3.4%
Compound 4: middle estimate off by 1.6 percentage points, on the high side; measured number inside the range.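

In this assay chloro in place of methyl gives a number 0.3 percentage points higher from compound 3 to compound 4 (within the scatter) and so agrees with the same swap on the core without sulfamoyl: the same change on two cores in this assay, a number 2.3 percentage points higher (within the scatter) from compound 2 to compound 1 and a number 0.3 percentage points higher (within the scatter) from compound 3 to compound 4, 2 percentage points apart, within the scatter of two such steps. Sulfamoyl in place of hydrogen gives a number 5.9 percentage points lower from compound 1 to compound 4 (within the scatter) and likewise agrees with its earlier step: the same change on two cores in this assay, a number 3.9 percentage points lower (within the scatter) from compound 2 to compound 3 and a number 5.9 percentage points lower (within the scatter) from compound 1 to compound 4, 2 percentage points apart, within the scatter of two such steps. Within the data shown here, both changes together give a number 3.6 percentage points lower from compound 2 to compound 4 (within the scatter) and all these steps stay within the scatter, which shows only that neither change measurably moved the read-out at this one concentration, not that a larger effect would carry over from one core to another.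

The compounds shown leave open whether a methoxy or a fluoro in place of the chloro, or an amine or a carboxylic acid in place of the sulfamoyl, would give a step beyond the scatter.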